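Swapping methylamino for sulfanyl on a chlorinated core

This account rests on a few compounds, and the source may have more. Where it says the series, first, only, none or still open, it means among the compounds named here.

Compound 1 `OCCOCn1c(Cl)nc2cc(Cl)c(Cl)cc21` gives in a functional assay on KB cells (Homo sapiens) for inhibition (on this read-out higher numbers stand for weaker inhibition and lower numbers for stronger inhibition), a limit of > 320000 nM.
Compound 2 `CNc1nc2c(Cl)c(Cl)ccc2n1COCCO` gives in this assay a limit of > 100000 nM.
Compound 3 `OCCOCn1c(S)nc2c(Cl)cc(Cl)cc21` gives in this assay a limit of > 100000 nM.

None of the three measured compounds yields a number in this assay; each sits at a limit of the assay. Compound 2 stands at the limit described in the limit of > 100000 nM in this assay, at which 2 of the 3 values shown sit, shared with compound 3, while compound 1 sits at the limit described in the limit of > 320000 nM in this assay, at which 1 of the 3 values shown sits. Compound 2 is therefore not placed anywhere on a scale of measured inhibition; it is simply too weak for the assay to report a value.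

Compound 4 `OCCOCn1c(S)nc2c(Cl)c(Cl)ccc21` carries the change (sulfanyl in place of methylamino on an aromatic carbon), in words: sulfanyl in place of methylamino on an aromatic carbon. Within the data shown here, no step between two measured compounds is available to show what this exchange does. Compound 3, which also carries a sulfanyl group on its shared core, sits at a limit in this assay, so there is no sign that this group brings inhibition into the measurable range. The expectation for compound 4 is therefore no step beyond the scatter, that is a step that the limit leaves unreadable from compound 2 to compound 4, and compound 4 is estimated at 150000 nM, between 50000 nM and 1000000 nM, most likely reported again only as a limit.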

Compound 4, half-maximal inhibitory concentration: > 100000 nM
Compound 4 ended at the assay's limit; the forecaster's own chance of this, stated with the estimate: 85%; the middle value does not contradict the limit.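

In this assay, among these compounds, compound 2 and compound 4 both sit at a limit rather than at a number, so no step between them can be read. The compounds shown leave open whether any group on this aromatic carbon brings inhibition into the measurable range.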